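The source may report more compounds than this note shows. Statements on the series, on what has been measured and on what is new or still open speak of the compounds shown alone.

Measured so far:
- compound 1 `CN(C)c1ccc2c(=O)c(C(=O)Nc3cc(F)cc(F)c3)cn(-c3ccc(OCCCCCCC[n+]4ccccc4)cc3Cl)c2n1`: "not active" (no number reported)
- compound 2 `Cc1ccc(-n2cc(C(=O)Nc3cc(F)cc(F)c3)c(=O)c3ccc(N(C)C)nc32)cc1OCCCCCCC[n+]1ccccc1`: 22.2%
- compound 3 `CN(C)c1ccc2c(=O)c(C(=O)Nc3cc(F)cc(F)c3)cn(-c3ccc(Cl)c(OCCCCCCC[n+]4ccccc4)c3)c2n1`: 77.9%

In an assay on LX2 cells for inhibition of COL1A1 promoter (Homo sapiens), read by a luciferase reporter, with a stated time of 24 h, tested at 50 uM (a lower number here means a weaker effect, a higher number a stronger effect of the compound at the concentration tested), compound 3 stands highest of the two numbers reported. Among the compounds with values here, its nearest neighbour is compound 2, and the single measured step, a number 55.7 percentage points higher from compound 2 to compound 3 (beyond the scatter), separates the two; that step is a chloro in place of a methyl on an aromatic carbon. Compound 1 is reported only as "not active" (no number reported), without a number, and cannot be placed on the scale.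

Compound 4 `CN(C)c1ccc2c(=O)c(C(=O)Nc3cc(F)cc(F)c3)cn(-c3ccc(Cl)c(OCCCCCCC[N+](C)(C)C4CCCCC4)c3)c2n1` is the next step from compound 3. The change is a group of 9 heavy atoms (8 carbon, 1 nitrogen; one six-membered non-aromatic ring of carbon only) in place of a group of 6 heavy atoms (5 carbon, 1 nitrogen; one six-membered aromatic ring with 1 hetero atom), on a saturated chain carbon, seven bonds along the chain from an oxygen on an aromatic ring. The charged end of the chain is altered; the ring bearing the chloro and the chain, the amide and the shared core stay as in compound 3. Within the data shown here, no measured step touches the chain end: the one step known, a number 55.7 percentage points higher from compound 2 to compound 3 (beyond the scatter), sits on the aromatic ring and says nothing about this position. There is therefore no basis for expecting a step beyond the scatter in either direction, and the expectation is that compound 4 stays close to compound 3, with a step of a number 9.9 percentage points lower from compound 3 to compound 4 (within the scatter) that is small. Compound 4 is estimated at 68%, in a range from 35% to 90%, the width reflecting the absence of any measured step at this position.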

Compound 4, a percentage reported as inhibition, at one concentration (the size of the read-out at that concentration, not a potency): 81.4%
Compound 4: middle estimate off by 13.4 percentage points, on the low side, and the stated range covers the measured number.
By their numbers in this assay, from the lowest: compound 2; then compounds 3 and 4 (each within the scatter of the next).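

In this assay, the chain end accepts a large replacement without a clear effect on the read-out: a number 3.5 percentage points higher from compound 3 to compound 4 (within the scatter), so the two compounds cannot be ordered. Within the data shown here, this is the first measured information at this position, on a saturated chain carbon, seven bonds along the chain from an oxygen on an aromatic ring, and it shows that, in this pair, the six-membered aromatic ring with 1 hetero atom is not needed at the chain end; a group with one six-membered non-aromatic ring of carbon only, also of net charge +1, serves in its place at the single concentration tested. No measurement at hand accounts for this result.

Both chain ends compared here carry net charge +1, so the compounds shown leave open whether the charge matters, which a neutral tertiary amine or a carboxylic acid at the chain end would test. Among these compounds, also open are the effect of a shorter or longer chain and whether the chloro-for-methyl step on the aromatic ring holds with the new chain end, as this pair is the only comparison at this position and gives no potency.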